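The source may hold more compounds than are shown below. What is called first, only, known or untested is meant among the compounds shown, and "the series" means these compounds.

Compound 1 `COc1cc(OC)c(/C=C/C(=O)/C=C/c2cc3ccccc3nc2Cl)c(OC)c1`: > 10000 nM
Compound 2 `COc1cc(OC)c(/C=C/C(=O)/C=C/c2cc3ccccc3nc2Oc2ccc(Br)cc2)c(OC)c1`: > 10000 nM
Compound 3 `COc1cc(OC)c(OC)cc1/C=C/C(=O)/C=C/c1cc2ccccc2nc1Oc1cccc(Cl)c1`: > 10000 nM

All three were tested in a functional assay on HeLa cells (Homo sapiens) for cytotoxicity, read by MTT assay, with a stated time of 48 h (a lower number here means a stronger inhibitor, a higher number a weaker inhibitor), and each entry is a limit of the assay, not a number. Compound 3 thus stands only at a limit, > 10000 nM. Compound 4 `COc1cc(OC)c(/C=C/C(=O)/C=C/c2cc3ccccc3nc2Oc2cccc(Cl)c2)c(OC)c1` has the same atoms, joined differently: 2,4,6-trimethoxyphenyl in place of 2,4,5-trimethoxyphenyl on a double-bonded chain carbon bound to a double-bonded chain carbon. Within the data shown here, the one measured step, a step that the two limits leave unreadable from compound 1 to compound 2, concerns a different group and gives no size to carry over. Compounds 1 and 2 already carry 2,4,6-trimethoxyphenyl, and the whole set shows (the limit of > 10000 nM in this assay, at which 3 of the 3 values shown sit). No step beyond the scatter is therefore expected in this assay, and no direction can be given. The estimated step is a step that the limit leaves unreadable from compound 3 to compound 4. For compound 4 the expected value is 15000 nM, with an estimated range from 4000 nM to 50000 nM.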

Compound 4, half-maximal inhibitory concentration: > 10000 nM
Compound 4 was reported as a limit; the forecaster's own chance of this, stated with the estimate: 70%; the middle value is on the limit's open side.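

Compound 4 is also reported only as a limit, so no step to it from compound 1, compound 2 or compound 3 can be read: the limit of > 10000 nM in this assay, at which 4 of the 4 values shown sit.

The compounds shown leave open whether 2,4,6-trimethoxyphenyl and 2,4,5-trimethoxyphenyl differ in strength at all.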